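Moving the chlorine around one phenyl ring

The compounds below may be only part of what the source reports. "The series", "measured", "known", "first", "only" and "open" are said of these compounds alone.

Four close relatives share a single core: a central six-membered ring bearing a 4-hydroxyphenyl group, a pyridyl group and a chlorophenyl group. Compound 1 `Oc1ccc(-c2cc(-c3cccc(Cl)c3)nc(-c3ccccn3)c2)cc1` has been tested in an ADME assay on HEK293 cells (Homo sapiens) for cytotoxicity, read by CCK-8 assay and cell counting, with a stated time of 2 days (a higher number here means a weaker inhibitor, a lower number a stronger inhibitor), and gives 25400 nM, a weak effect on cell survival. Compound 2 `Oc1ccc(-c2cc(-c3ccncc3)nc(-c3ccc(Cl)cc3)c2)cc1` and compound 3 `Oc1ccc(-c2cc(-c3ccccn3)nc(-c3ccccc3Cl)c2)cc1` were also prepared. In this assay compound 2 gives "not determined" (no result reported), and in the same assay compound 3 gives "not determined" (no result reported), so compound 3 stands without a number of its own, and one further compound shares that position. Compound 4 `Oc1ccc(-c2cc(-c3ccc(Cl)cc3)nc(-c3ccccn3)c2)cc1` is the next member and has not yet been measured in this assay.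

The difference between compound 3 and compound 4 is modest: 4-chlorophenyl in place of 2-chlorophenyl on an aromatic carbon. The two compounds contain the same atoms, joined differently. For the measured compounds named here, no measured pair differs in only one place, so the size of such a step cannot be read off from data. For a change of this kind, a shift no larger than the usual scatter of this assay is expected, in no particular direction; the one measured relative, compound 1, another chlorophenyl isomer, gives 25400 nM. Compound 4 is therefore expected to give about 25000 nM in this assay, with a plausible range from 8000 nM to 80000 nM.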

Compound 4, half-maximal inhibitory concentration: 27200 nM
Estimate against measurement, compound 4: 1.1-fold (0.04 log units) below; low and high end bracket the measured number.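

For the compounds shown here, this is the first step that can be read: in this assay, 4-chlorophenyl in place of 3-chlorophenyl gives a 1.1-fold higher number from compound 1 to compound 4 (0.03 log units; within the scatter) and so leaves the two isomers indistinguishable. On this aromatic carbon, next to the ring nitrogen, moving the chlorine between these two places on the phenyl ring therefore makes no measurable difference to the effect on cell survival, although this holds only for this one pair. Nothing measured here speaks to why the two compounds read alike.

Steps involving compound 2 and compound 3 cannot be read, as neither has a number, so it remains open whether the 2-chlorophenyl group of compound 3 would read like the other two isomers. Every compound shown also carries a chlorine on this phenyl ring, which leaves open whether a different group there, such as an amine or a carboxylic acid, would shift the result beyond the usual scatter of repeated measurements.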